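From ethoxy to methoxy in a small ester series

The compounds below may be only part of what the source reports. "The series", "measured", "known", "first", "only" and "open" are said of these compounds alone.

In a functional assay on HBL-100 cells (Homo sapiens) for antiproliferative activity, read by sulforhodamine B assay, with a stated time of 48 h (a higher number here means a weaker inhibitor of growth, a lower number a stronger inhibitor of growth), compound 3 (`CCOC(=O)C#CC(O/C=C/C(=O)OCC)C(C)C`) gives 3000 nM and holds the higher of the two actual numbers in this small set. In this assay compound 1 (`CCCCC(C#CC(=O)OC)O/C=C/C(=O)OC`) gives 250 nM and lies lower than compound 3 by a gap beyond the scatter. Compound 2 (`CCCCCCC(C#CC(=O)O)O/C=C/C(=O)OC`) shows > 100000 nM which is a limit of the assay and not a number.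

Compound 4 (`CCOC(=O)C#CC(O/C=C/C(=O)OC)C(C)C`) has yet to be measured. Its difference from compound 3 is hydrogen in place of methyl on a saturated chain carbon bound to an oxygen next to a carbonyl group and amounts to hydrogen in place of methyl on a saturated chain carbon bound to an oxygen next to a carbonyl group, with ethoxycarbonyl becoming methoxycarbonyl. For the measured compounds named here, no measured pair isolates this change. Compound 1 at 250 nM differs from compound 3 in more than this one place and offers only a loose guide. In this assay no step beyond the scatter is expected, and the estimated 1.3-fold lower number from compound 3 to compound 4 (0.10 log units; within the scatter) stays small. For compound 4 the expected value is 2400 nM with an estimated range from 700 nM to 8000 nM in this assay.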

Compound 4, concentration for 50% growth inhibition: 880 nM
Estimate against measurement, compound 4: 2.7-fold (0.44 log units) above; measured number inside the range.
By their numbers in this assay, from the lowest: compound 1; then compound 4; then compound 3. At a limit, above all of these: compound 2.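

this assay now holds one comparison that can be read at a single place: ethoxycarbonyl becoming methoxycarbonyl, with hydrogen in place of methyl on a saturated chain carbon bound to an oxygen next to a carbonyl group, gives a 3.4-fold lower number from compound 3 to compound 4 (0.53 log units; beyond the scatter) in this small set. Compound 1, compound 2 and compound 3 differ from one another in more than one place, whereas this modest step shows that this one change alone can move the number beyond the scatter. Nothing measured here gives a cause for the step.

Open, going by these compounds, is whether a longer chain at this ester, such as propoxycarbonyl, or a carboxylic acid there would move the number further or reverse the step. Also open, on these data alone, is whether changing the remaining ethoxycarbonyl of compound 4 would close the gap to compound 1 at 250 nM, which differs in more than one place.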